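From isopropyl to cyclobutyl on a carbonyl carbon

A few compounds are considered here, and "the series" means these few. Any claim that something is new, unique, unknown or untested is made for them only; others in the source may bear on it.

Compound 1 `O=C(C1CCOC1)N1N=CCC1c1ccccc1` gives 3
Compound 2 `CC(C)C(=O)N1N=CCC1c1ccccc1` gives 4.4
Compound 3 `CC(C)(C)C(=O)N1N=CCC1c1cccnc1` gives 3.2

These numbers come from a physicochemical assay for lipophilicity, read by HPLC, measured as chromatographic lipophilicity, at pH 7.4; a lower number here means a more polar compound, a higher number a more lipophilic compound. Compound 2 stands highest of the three, clearly above both compound 3 and compound 1. Compound 4 `O=C(C1CCC1)N1N=CCC1c1ccccc1` has not been measured, and it carries cyclobutyl in place of isopropyl on a carbonyl carbon. For the measured compounds named here, no measured step swaps these two groups. The closest guide is a number 1.40 log units higher from compound 1 to compound 2 (beyond the scatter), a large step at the same place, but it involves oxolan-3-yl, whereas the new swap stays among groups of carbon only. A much smaller change is therefore expected, slightly upward if anything, and the estimated step is a number 0.10 log units higher from compound 2 to compound 4 (within the scatter). The expected value for compound 4 is 4.5, within an estimated range from 4.1 to 4.9.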

Compound 4, distribution coefficient: 4.7
Compound 4: middle estimate off by 0.20 log units, on the low side, within the range that was stated.
By their numbers in this assay, from the lowest: compounds 1 and 3 (each within the scatter of the next); then compounds 2 and 4 (each within the scatter of the next).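

In this assay, the swap on the carbonyl carbon gives a number 0.30 log units higher from compound 2 to compound 4 (within the scatter), so at this place, isopropyl and cyclobutyl cannot be told apart, even though cyclobutyl brings a ring. Set against oxolan-3-yl, cyclobutyl gives a number 1.70 log units higher from compound 1 to compound 4 (beyond the scatter), a large step in the same direction as a number 1.40 log units higher from compound 1 to compound 2 (beyond the scatter). Both groups of carbon only therefore stand well clear of oxolan-3-yl here.

On these data alone, it remains open whether an amine or a longer chain such as n-pentyl would read like these carbon groups or like oxolan-3-yl. Nothing available explains the size of these steps.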